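Aryl swaps on the triazole nitrogen: cytotoxicity notes

This account rests on a few compounds, and the source may have more. Where it says the series, first, only, none or still open, it means among the compounds named here.

Measured so far:
compound 1 `CC(C)c1ccc(-n2nc(-c3ccc(C(F)(F)F)cc3O)nc2-c2ccccc2O)cc1`: 108%
compound 2 `Oc1cc(C(F)(F)F)ccc1-c1nc(-c2ccccc2O)n(-c2ccccc2F)n1`: 100%
compound 3 `Oc1cc(C(F)(F)F)ccc1-c1nc(-c2ccccc2O)n(-c2ccccc2C(F)(F)F)n1`: 92.2%

In a functional assay on PC-12 cells (Rattus norvegicus) for cytotoxicity, read by MTT assay, with stated times of 2 h and 24 h, tested at 10 uM (on this read-out higher numbers stand for a stronger effect at the one concentration tested and lower numbers for a weaker effect), compound 3 gives the lowest of the three numbers; compound 2 sits within the scatter of it, and only compound 1 lies beyond. Compound 4 `Oc1cc(C(F)(F)F)ccc1-c1nc(-c2ccccc2O)n(-c2cc(F)cc(F)c2)n1` is not yet measured; it differs from compound 3 in one place: 3,5-difluorophenyl in place of 2-(trifluoromethyl)phenyl on an aromatic nitrogen.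

All three measured steps change the group on this same aromatic nitrogen. Two are within the scatter, a number 8 percentage points lower from compound 1 to compound 2 (within the scatter) and a number 7.8 percentage points lower from compound 2 to compound 3 (within the scatter), and one is modest, a number 15.8 percentage points lower from compound 1 to compound 3 (beyond the scatter). A fourth aryl swap at this position is therefore expected to move the read-out in this assay little, if at all, beyond the scatter; the direction is not predictable from these three compounds.

Compound 4 is expected to give 96% in this assay, with a range from 80% to 112%. That estimate means an expected step of a number 3.8 percentage points higher from compound 3 to compound 4 (within the scatter).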

Compound 4, a percentage reported as activity, at one concentration (the size of the read-out at that concentration, not a potency): 106%
Beside the measured number, compound 4's estimate is 10 percentage points below it; the range from low to high includes it.
By their numbers in this assay, from the lowest: compounds 3, 2, 4 and 1 (each within the scatter of the next, the first and the last beyond it).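

The swap gives a number 13.8 percentage points higher from compound 3 to compound 4 (beyond the scatter) in this assay, the first step upward beyond the scatter at this aromatic nitrogen, so the lowered number of compound 3 does not extend to 3,5-difluorophenyl. The other two comparisons, a number 6 percentage points higher from compound 2 to compound 4 (within the scatter) and a number 2 percentage points lower from compound 1 to compound 4 (within the scatter), place compound 4 level with both, so 3,5-difluorophenyl matches 2-fluorophenyl and 4-isopropylphenyl here. Nothing available explains the difference between these aryl groups.

All four compounds carry an aryl group on this nitrogen. Open, from the compounds shown here alone, is how the read-out responds to an amine or carboxylic acid on that ring, or to a longer alkyl chain in its place.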